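The source may report more compounds than this note shows. Statements on the series, on what has been measured and on what is new or still open speak of the compounds shown alone.

Measured so far in a functional assay on MCF7 cells (Homo sapiens) for antiproliferative activity, read by MTT assay, with a stated time of 72 h; on this read-out higher numbers stand for weaker inhibition and lower numbers for stronger inhibition:
- Compound 1 `CCN1CCN(c2cc(C)c3cc(NC(=O)c4ccc(F)cc4)ccc3n2)CC1`: 4030 nM
- Compound 2 `CCN1CCN(c2cc(C)c3cc(NC(=O)c4ccccc4Cl)ccc3n2)CC1`: > 50000 nM

Compound 2 stands at the limit of > 50000 nM in this assay, at which 1 of the 2 values shown sits, so its entry is a limit and not a number. Compound 3 `CCc1ccc(C(=O)Nc2ccc3nc(N4CCN(CC)CC4)cc(C)c3c2)cc1` has 4-ethylphenyl in place of 2-chlorophenyl on a carbonyl carbon. Going by the values given here, only one measured step bears on this change: an at least 12-fold higher number from compound 1 to compound 2 (1.09 log units; beyond the scatter), a large step that put 2-chlorophenyl in place of 4-fluorophenyl at the same carbonyl carbon. Among the compounds with values here, removing 2-chlorophenyl again should therefore give a large step towards a lower number in this assay, though the new group differs from the one in compound 1. The expected change is an at least 7.1-fold lower number from compound 2 to compound 3 (0.85 log units; beyond the scatter). For compound 3 the estimated value is 7000 nM, with an expected range of 2000 nM to 30000 nM.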

Compound 3, half-maximal inhibitory concentration: 3060 nM
The estimate for compound 3 lay 2.3-fold (0.36 log units) above the measured number, within the range that was stated.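

Putting 4-ethylphenyl in place of 2-chlorophenyl on the carbonyl carbon gives an at least 16-fold lower number from compound 2 to compound 3 (1.21 log units; beyond the scatter). The entry for compound 2 is a limit and not a number: the limit of > 50000 nM in this assay, at which 1 of the 3 values shown sits. Ethyl in place of fluoro on an aromatic carbon gives a 1.3-fold lower number from compound 1 to compound 3 (0.12 log units; within the scatter), so 4-fluorophenyl and 4-ethylphenyl cannot be told apart on this read-out.

The compounds shown do not separate the effect of the chlorine itself from that of where it sits on the phenyl ring. On these data alone, how 4-chlorophenyl, or a phenyl ring carrying an amine or a carboxylic acid, would fare also stays open.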